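Cytotoxicity of a Fluorophenyl Analogue in Fibroblasts

This account rests on a few compounds, and the source may have more. Where it says the series, first, only, none or still open, it means among the compounds named here.

Compound 1 `CC(C)(Oc1ccc(Cl)cc1)C(=O)NCCOC(=S)Nc1ccc([N+](=O)[O-])cc1Cl` was tested in an ADME assay on WI-38 cells (Homo sapiens) for cytotoxicity, read by MTT assay, with a stated time of 48 h; on this read-out higher numbers stand for weaker inhibition and lower numbers for stronger inhibition. In this assay compound 1 reaches only a limit, > 800000 nM, and gives no number. Among the three measured compounds it sits at the limit of > 800000 nM in this assay, at which 2 of the 3 values shown sit. Compound 3 `O=C(NCCOC(=S)Nc1ccc(F)cc1)c1cccnc1`, which also bears 4-fluorophenyl on an amide-type nitrogen, likewise reaches only a limit in this assay, > 800000 nM. Compound 2 `CC(C)(Oc1ccc(Cl)cc1)C(=O)Oc1ccc(-c2cc(=S)ss2)cc1` gives 764000 nM in this assay. Compound 4 `CC(C)(Oc1ccc(Cl)cc1)C(=O)NCCOC(=S)Nc1ccc(F)cc1` differs from compound 1 by 4-fluorophenyl in place of 2-chloro-4-nitrophenyl on an amide-type nitrogen. With compound 1 and compound 3 both at the limit, the expected step of a number no higher from compound 1 to compound 4 (the limit leaves the size open) is none beyond the scatter. Compound 4 is therefore expected to give 800000 nM in this assay, between 400000 nM and 1600000 nM, most likely again only as a limit.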

Compound 4, half-maximal inhibitory concentration: > 800000 nM
Compound 4: a limit, no number; the forecaster's own chance of this, stated with the estimate: 80%; the middle value sits exactly at the limit.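

Among the compounds shown here, compound 1 and compound 4 both reach only a limit in this assay, so no step between them can be read. The compounds shown leave open whether 4-fluorophenyl in place of 2-chloro-4-nitrophenyl changes cytotoxicity at all.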